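The compounds below may be only part of what the source reports. "The series", "measured", "known", "first", "only" and "open" are said of these compounds alone.

Measured so far:
- compound 1, `N#Cc1c(Nc2ccccc2Cl)nc(SCc2cn(Cc3ccccc3Cl)nn2)nc1-c1ccccc1`, which in a functional assay on ECa-109 cells (Homo sapiens) for inhibition, read by MTT assay, with a stated time of 72 h (on this read-out lower numbers stand for stronger inhibition and higher numbers for weaker inhibition), gives 28500 nM;
- compound 2, `N#Cc1c(Nc2cccc([N+](=O)[O-])c2)nc(SCc2cn(Cc3ccccc3Cl)nn2)nc1-c1ccccc1`, for which this assay reports only a limit, > 64000 nM;
- compound 3, `N#Cc1c(Nc2ccccc2F)nc(SCc2cn(Cc3ccccc3Cl)nn2)nc1-c1ccccc1`, which in this assay gives 23000 nM.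

Compound 3 has the lowest of the two numbers shown, though compound 1 sits close to it (a 1.2-fold lower number from compound 1 to compound 3 (0.09 log units; within the scatter)). Compound 4, `Cc1ccc(Nc2nc(SCc3cn(Cc4ccccc4Cl)nn3)nc(-c3ccccc3)c2C#N)cc1`, is not yet measured. It differs from compound 3 in one place: 4-methylphenyl in place of 2-fluorophenyl on a nitrogen on an aromatic ring.

Two measured steps change the same phenyl group on the same nitrogen. Swapping one ortho-halogen for another barely moves the number (a 1.2-fold lower number from compound 1 to compound 3 (0.09 log units; within the scatter)), whereas moving to 3-nitrophenyl pushes the number up to the limit (an at least 2.2-fold higher number from compound 1 to compound 2 (0.35 log units; beyond the scatter); (the limit of > 64000 nM in this assay, at which 1 of the 3 values shown sits)), and returning to 2-fluorophenyl brings it back down (an at least 2.7-fold lower number from compound 2 to compound 3 (0.44 log units; beyond the scatter)). Among the compounds with values here, no measured compound carries a 4-methylphenyl, so the step to compound 4 is uncertain, but a modest rise or no change beyond the scatter seems most likely. For compound 4 the expected step is a 1.3-fold higher number from compound 3 to compound 4 (0.12 log units; within the scatter). Compound 4 is therefore estimated at 30000 nM, between 12000 nM and 75000 nM.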

Compound 4, half-maximal inhibitory concentration: > 64000 nM
Compound 4: no number, only a limit (the forecaster's own chance of this, stated with the estimate: 20%); at least 2.1-fold (0.32 log units) between middle value and limit.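

In this assay, compound 4 gives only a limit, > 64000 nM. Replacing the halogen-bearing ring with 4-methylphenyl therefore raises the number beyond the scatter, shown by an at least 2.7-fold higher number from compound 3 to compound 4 (0.44 log units; beyond the scatter) and by an at least 2.2-fold higher number from compound 1 to compound 4 (0.35 log units; beyond the scatter). Before this result, only 3-nitrophenyl had reached the limit; now a ring carrying only a methyl group has as well, so among these compounds only 2-chlorophenyl and 2-fluorophenyl give actual numbers: the limit of > 64000 nM in this assay, at which 2 of the 4 values shown sit.

The step between compound 2 and compound 4 cannot be read, as both values are limits. As far as these compounds go, it remains open whether a plain phenyl group, or a phenyl ring carrying a methoxy group, would give a number, and so whether the halogen itself matters or only where a group sits on the ring.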